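Swapping the side group at the acetal carbon of compound 3

The source may hold more compounds than are shown below. What is called first, only, known or untested is meant among the compounds shown, and "the series" means these compounds.

In a functional assay for inhibition, with Homo sapiens as the target (on this read-out lower numbers stand for tighter binding and higher numbers for weaker binding), three compounds of one shared core have been measured. Compound 1 `O=C(O)CC/C=C\CC1COC(c2ccc([N+](=O)[O-])cc2)OC1c1cccnc1` gives 933 nM. For the measured compounds named here, compound 2 `O=C(O)CC/C=C\CC1COC(c2ccc3ccccc3c2)OC1c1cccnc1` gives 1780 nM; the only measured one-place step, a 1.9-fold higher number from compound 1 to compound 2 (0.28 log units; within the scatter), falls within the scatter. Compound 3 `CC(C)(C)c1ccc(OC(C)(C)C2OCC(C/C=C\CCC(=O)O)C(c3cccnc3)O2)cc1` gives 1910 nM, which puts it at the upper end of the three numbers: its gap to compound 2 lies within the scatter, while compound 1 sits lower by a gap beyond the scatter.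

Compound 4 `CC(C)(Cc1ccc(F)cc1C#N)C1OCC(C/C=C\CCC(=O)O)C(c2cccnc2)O1` has not yet been measured. It differs from compound 3 in one place: a group of 10 heavy atoms (8 carbon, 1 nitrogen, 1 fluorine; one six-membered aromatic ring of carbon only) in place of a group of 11 heavy atoms (10 carbon, 1 oxygen; one six-membered aromatic ring of carbon only), on a saturated chain carbon bound to two saturated chain carbons and a saturated ring carbon

Going by the values given here, no measured step touches this place. Among the compounds with values here, the one step on record, from compound 1 to compound 2, alters the group on a saturated ring carbon, not the saturated chain carbon changed here, and it stayed within the scatter in any case. There is thus nothing in the data that points to a large shift in either direction for this assay, and the expectation is a step of no more than the usual scatter, a 1.3-fold lower number from compound 3 to compound 4 (0.10 log units; within the scatter), with a wide margin on either side.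

Compound 4 is therefore estimated at 1500 nM, with a range from 450 nM to 5000 nM.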

Compound 4, dissociation constant: 2.19 nM
Estimate against measurement, compound 4: 680-fold (2.84 log units) above; the whole stated range lies above it.
By their numbers in this assay, from the lowest: compound 4; then compounds 1, 2 and 3 (each within the scatter of the next, the first and the last beyond it).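

In this assay, the place on a saturated chain carbon bound to two saturated chain carbons and a saturated ring carbon proves highly sensitive: the swap of the 4-(tert-butyl)phenoxy group for the group carrying a nitrile and a fluorine gives an 870-fold lower number from compound 3 to compound 4 (2.94 log units; beyond the scatter). For the compounds shown here, the only earlier step, at a different place, stayed within the scatter, so this is the first sign that a one-place change on this core can move the number by a large amount, even though the two groups are close in heavy-atom count and each has one six-membered aromatic ring of carbon only, the same hydrogen-bond counts and no net charge. Nothing measured here explains why the number moved so far.

The swap removes the oxygen and the tert-butyl group and brings in the nitrile and the fluorine all at once, so the compounds shown cannot say which of these parts carries the step. Also open, as far as these compounds go, is how this place would respond to a chlorine or a methoxy group standing in for the nitrile or the fluorine, or to a longer chain joining the aromatic ring to the saturated chain carbon.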